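The compounds below may be only part of what the source reports. "The series", "measured", "known", "first", "only" and "open" are said of these compounds alone.

Of the compounds shown here, three have been measured in an ADME assay on cells (Hepatocyte, Rattus norvegicus) for metabolic stability; on this read-out higher numbers stand for fast clearance and lower numbers for slow clearance. Compound 1 `CS(=O)(=O)c1cnc(Nc2ccc(O)cc2)nc1NCc1ccccc1` gives 32 uL/min in this assay. Compound 2 `CNC(=O)c1sc(N2CC3CC2(CNC(=O)c2c[nH]c4ncc(Cl)cc24)C3)nc1C(F)(F)F` gives 120 uL/min in this assay. Compound 3 `CNC(=O)c1cnc(Nc2ccc(OC)cc2C)nc1NC1CCCC1` gives 130 uL/min in this assay. Among these three numbers compound 2 stands second highest: its value and that of compound 3 lie within the usual scatter of each other, so no order can be read between them, while the number of compound 1 is lower by a margin that lies beyond the scatter.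

The step under consideration leads from compound 2 to compound 4 `CNC(=O)c1sc(N2CC3CC2(CNC(=O)c2c[nH]c4ncc(C)cc24)C3)nc1C(F)(F)F`, which has not yet been measured in this assay. The structural change is a single one: methyl in place of chloro on an aromatic carbon. A chloro leaves and a methyl enters on an aromatic carbon of a six-membered aromatic ring with one nitrogen, part of a fused or bridged system of two rings, two atoms from the ring nitrogen. Within the data shown here, no measured pair in this set differs in this one place, so nothing here shows how such an exchange moves the read-out of this assay. The step from compound 2 to compound 4 is therefore expected to be a 1.2-fold higher number from compound 2 to compound 4 (0.07 log units; within the scatter), a change that stays within the scatter and carries no clear direction. On this basis compound 4 is estimated at 140 uL/min in this assay, with a range from 70 uL/min to 280 uL/min.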

Compound 4, intrinsic clearance in a liver preparation (reported as CLH), per the amount of preparation that the assay uses: 92 uL/min
Compound 4: middle estimate off by 1.5-fold (0.18 log units), on the high side; measured number inside the range.
By their numbers in this assay, from the lowest: compound 1; then compounds 4, 2 and 3 (each within the scatter of the next).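

In this assay, among these compounds, the exchange of chloro for methyl gives a 1.3-fold lower number from compound 2 to compound 4 (0.12 log units; within the scatter), a step that stays within the scatter, and this is the first pair in the set to differ in this one place. At this aromatic carbon, two atoms from the ring nitrogen of the six-membered aromatic ring, the read-out therefore does not separate the chloro group from the methyl group, and the step supports no direction for the exchange, only the statement that this one pair shows no clear effect on clearance. Nothing available bears on why the two compounds read alike, so the result stands as an observation without an explanation.

The compounds shown leave open whether any other group on this aromatic carbon, such as a methoxy group, a nitrile, an amine or plain hydrogen, would move the number beyond the scatter. They also leave open whether methyl in place of chloro would stay as quiet on another core, or elsewhere on this one, since this single pair is all that speaks to the exchange.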